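Enlarging the ring substituent on a monobactam core

This account rests on a few compounds, and the source may have more. Where it says the series, first, only, none or still open, it means among the compounds named here.

Compound 2 `CC(C)(O/N=C(\C(=O)N[C@@H]1C(=O)N(S(=O)(=O)O)[C@@H]1CN1CCC1=O)c1csc(N)n1)C(=O)O` carries a 2-oxoazetidin-1-yl group on a saturated chain carbon bound to a saturated ring carbon. In a physicochemical assay for metabolic stability, read by HPLC and mass spectrometry, in phosphate buffer, at 37 degrees C, at pH 7.4 (on this read-out lower numbers stand for a shorter-lived compound and higher numbers for a longer-lived compound), compound 2 gives only a limit, > 1000 h, and that limit is the limit of > 1000 h in this assay, at which 1 of the 3 values shown sits. Compound 1 `CN(C[C@@H]1[C@H](NC(=O)/C(=N\OC(C)(C)C(=O)O)c2csc(N)n2)C(=O)N1S(=O)(=O)O)C(=O)CN` gives 212 h, and compound 3 `CC(C)(O/N=C(\C(=O)N[C@@H]1C(=O)N(S(=O)(=O)O)[C@@H]1CN1CCCCC1=O)c1csc(N)n1)C(=O)O` gives 214 h. Going by the values given here, two measured steps bear on the position: an at least 4.7-fold higher number from compound 1 to compound 2 (0.67 log units; beyond the scatter), and an at least 4.6-fold lower number from compound 2 to compound 3 (0.66 log units; beyond the scatter); while a 1.0-fold higher number from compound 1 to compound 3 (0.00 log units; within the scatter). Compound 4 `CC(C)(O/N=C(\C(=O)N[C@@H]1C(=O)N(S(=O)(=O)O)[C@@H]1CN1C[C@H](CNC(=N)N)OC1=O)c1csc(N)n1)C(=O)O` differs from compound 2 at the same place: a group of 11 heavy atoms (5 carbon, 4 nitrogen, 2 oxygen; one five-membered non-aromatic ring with 2 hetero atoms) in place of a group of 5 heavy atoms (3 carbon, 1 nitrogen, 1 oxygen; one four-membered non-aromatic ring with 1 hetero atom), on a saturated chain carbon bound to a saturated ring carbon. Both other groups at this position, in compound 1 and compound 3, sit near each other and well below compound 2, so the ring enlargement in compound 4 is expected to lower the number, and the step of an at least 3.3-fold lower number from compound 2 to compound 4 (0.52 log units; beyond the scatter) is the estimated result. Compound 4 is thus expected to give about 300 h in this assay, within a range of 100 h to 1200 h.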

Compound 4, half-life: > 37 h
Compound 4 was reported as a limit (the forecaster's own chance of this, stated with the estimate: 20%); the middle value does not contradict the limit.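

In this assay compound 4 gives > 37 h, which is a limit, so its steps from compound 1, compound 2 and compound 3 cannot be read. The compounds shown leave open what half-life compound 4 actually has and how it ranks against these three compounds.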